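The source may hold more compounds than are shown below. What is called first, only, known or untested is meant among the compounds shown, and "the series" means these compounds.

Two compounds built on one shared core are in view: compound 1 `C[C@]1(CN2CCc3nc(-c4ccc(C(F)(F)F)cc4)ccc3C2)Cn2cc([N+](=O)[O-])nc2O1` and compound 2 `C[C@]1(CN2CCc3nc(-c4ccc(Cl)cc4)ccc3C2)Cn2cc([N+](=O)[O-])nc2O1`. In an ADME assay on Vero cells (Chlorocebus sabaeus) for cytotoxicity, read by MTT assay, with a stated time of 72 h (on this read-out higher numbers stand for lower toxicity in this test and lower numbers for higher toxicity in this test), compound 1 gives > 32 ug/mL, and this is a limit of the assay rather than a measured number. For compound 2 the result in this assay is "not determined" (no result reported), so no number is shown for it. Of the values given, one sits at the limit of > 32 ug/mL in this assay, at which 1 of the 2 values shown sits, and the other is not reported, which leaves compound 2 without a place on the scale.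

Compound 3 `C[C@]1(CN2CCc3nc(-c4ccc(Cl)cc4F)ccc3C2)Cn2cc([N+](=O)[O-])nc2O1` differs from compound 2 by one change: fluoro in place of hydrogen on an aromatic carbon. Cut one bond further out, the change reads 4-chlorophenyl to 4-chloro-2-fluorophenyl. For the measured compounds named here, no measured step between two compounds exists here to show how large an effect such a change has in this assay, so a step of no size beyond the scatter, in either direction, is the plain expectation. Compound 3 is expected to give about 40 ug/mL in this assay, most likely within 16 ug/mL to 100 ug/mL.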

Compound 3, half-maximal cytotoxic concentration: > 32 ug/mL
Compound 3 was reported as a limit (the forecaster's own chance of this, stated with the estimate: 70%); the middle value lies beyond the limit too.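

No step can be read from compound 1 to compound 3 or from compound 2 to compound 3: compound 1 and compound 3 both stand at a limit of the assay, and compound 2 has no reported result. Still open, as far as these compounds go, is how far compound 1 and compound 3 lie past that limit, and whether fluoro in place of hydrogen shifts the result in this assay.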